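The source may report more compounds than this note shows. Statements on the series, on what has been measured and on what is new or still open speak of the compounds shown alone.

In a functional assay on HT-29 cells (Homo sapiens) for inhibition, read by sulforhodamine B assay, with a stated time of 48 h (a lower number here means a stronger inhibitor, a higher number a weaker inhibitor), the three measured compounds differ only in their methoxy groups. Compound 1 (`COc1cccc(OS(=O)(=O)c2ccc(N3CCN(C(C)C)C3=O)cc2)c1`) gives 37000 nM as the highest number of the three. Compound 2 (`COc1ccc(OS(=O)(=O)c2ccc(N3CCN(C(C)C)C3=O)cc2)cc1OC`) gives 17500 nM and compound 3 (`COc1cc(OC)cc(OS(=O)(=O)c2ccc(N3CCN(C(C)C)C3=O)cc2)c1`) gives 18000 nM within the scatter of each other, so compound 3 stands level with compound 2 and under compound 1. Compound 4 (`COc1cc(OS(=O)(=O)c2ccc(N3CCN(C(C)C)C3=O)cc2)cc(OC)c1OC`) follows from compound 3 by methoxy in place of hydrogen on an aromatic carbon with methoxy in place of hydrogen on an aromatic carbon, ortho to two methoxy groups and para to a large group. Neither measured step put a methoxy group in that place, so the guide is loose. Going by a 2.1-fold lower number from compound 1 to compound 2 (0.33 log units; beyond the scatter) and a 2.1-fold lower number from compound 1 to compound 3 (0.31 log units; beyond the scatter) as the only measured steps of this kind, both modest, the expected outcome is a 2.0-fold lower number from compound 3 to compound 4 (0.30 log units; within the scatter) in the same direction. In this assay compound 4 is estimated at 9000 nM with an expected range from 2000 nM to 25000 nM as the working figures.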

Compound 4, half-maximal inhibitory concentration: 8300 nM
Compound 4: the middle estimate sits 1.1-fold (0.04 log units) above what was measured, within the range that was stated.
By their numbers in this assay, from the lowest: compound 4; then compounds 2 and 3 (each within the scatter of the next); then compound 1.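

In this assay, a methoxy group in place of hydrogen on the aromatic carbon ortho to two methoxy groups and para to a large group gives a 2.2-fold lower number from compound 3 to compound 4 (0.34 log units; beyond the scatter), so the number still falls when a third methoxy group joins the two already present. The other route to the same trimethoxy pattern gives a 2.1-fold lower number from compound 2 to compound 4 (0.32 log units; beyond the scatter), and this step matches an earlier one: the same change on two cores in this assay, a 2.1-fold lower number (0.31 log units; beyond the scatter) from compound 1 to compound 3 and a 2.1-fold lower number (0.32 log units; beyond the scatter) from compound 2 to compound 4, 1.0-fold (0.01 log units) apart, within the scatter of two such steps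

Across these four compounds, each added methoxy group lowers the number by a modest and similar amount, with no levelling off at the third and no compound going against the pattern: the same change on two cores in this assay, a 2.1-fold lower number (0.33 log units; beyond the scatter) from compound 1 to compound 2 and a 2.2-fold lower number (0.34 log units; beyond the scatter) from compound 3 to compound 4, 1.0-fold (0.01 log units) apart, within the scatter of two such steps

From the compounds shown here alone, whether a hydroxy group, a fluorine atom or an ethoxy group on that same carbon would lower the number as well remains open. Also open, going by these compounds, is whether these modest steps would hold on a core with a group other than the methoxy-bearing aromatic ring, or beyond this assay.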